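Sulfamoyl in place of nitro: an open question

The source may report more compounds than this note shows. Statements on the series, on what has been measured and on what is new or still open speak of the compounds shown alone.

Compound 1 `N#CC1CN1C(=O)Nc1ccc([N+](=O)[O-])cc1` gives 6500 nM in a functional assay on OVCAR-3 cells (Homo sapiens) for inhibition; a lower number here means a stronger inhibitor, a higher number a weaker inhibitor. Compound 2 `N#CC1CN1C(=O)Nc1cccc2ccccc12` gives 5900 nM in this assay; the two numbers stand within the scatter of each other, so neither compound can be called the stronger. Compound 3 `N#CC1CN1C(=O)Nc1ccc(S(N)(=O)=O)cc1` differs from compound 1 by sulfamoyl in place of nitro on an aromatic carbon. Among the compounds with values here, no measured pair isolates this change, so nothing shows which way it pulls. The expected step of a 1.1-fold higher number from compound 1 to compound 3 (0.03 log units; within the scatter) is small, none beyond the scatter, with a wide margin either way. For compound 3 the estimate is 7000 nM, with a range from 2000 nM to 25000 nM.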

Compound 3, half-maximal inhibitory concentration: 188000 nM
Compound 3: the middle estimate sits 27-fold (1.43 log units) below what was measured; the measured number lies above the stated range.
By their numbers in this assay, from the lowest: compounds 2 and 1 (each within the scatter of the next); then compound 3.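

Sulfamoyl in place of nitro on an aromatic carbon gives a 29-fold higher number from compound 1 to compound 3 (1.46 log units; beyond the scatter) in this assay, so this position is not indifferent to the group it carries. Nitro goes with the stronger inhibitor here, and the change also brings in a sulfur and a hydrogen-bond donor, which this single pair cannot separate. No data here explain the size of the step.

Open, going by these compounds, is how an amine, a carboxylic acid or methylsulfonyl would read at this position. Also open, on these data alone, is whether any group here improves on nitro.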